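A few compounds are considered here, and "the series" means these few. Any claim that something is new, unique, unknown or untested is made for them only; others in the source may bear on it.

In a functional assay on SK-OV-3 cells (Homo sapiens) for antiproliferative activity, read by sulforhodamine B assay, with a stated time of 48 h (on this read-out higher numbers stand for weaker inhibition and lower numbers for stronger inhibition), three sulfonamides with a common core have been measured. Compound 1 (`O=C1NCCN1c1ccc(S(=O)(=O)Nc2ccc3[nH]ccc3c2)cc1`) gives 280 nM, compound 2 (`Cc1cccc(NS(=O)(=O)c2ccc(N3CCNC3=O)cc2)c1`) gives 200 nM, and compound 3 (`Cc1cc(C)cc(NS(=O)(=O)c2ccc(N3CCNC3=O)cc2)c1`) gives 190 nM. The value of compound 3 lies within the scatter of both others, so it cannot be ranked against them. The next structure is compound 4 (`COc1cccc(NS(=O)(=O)c2ccc(N3CCNC3=O)cc2)c1`), in which 3-methoxyphenyl replaces 3,5-dimethylphenyl on a sulfonamide nitrogen (3-methoxyphenyl in place of 3,5-dimethylphenyl on a sulfonamide nitrogen). Going by the values given here, only one measured step bears on this change: a 1.1-fold lower number from compound 2 to compound 3 (0.02 log units; within the scatter), with methyl in place of hydrogen on an aromatic carbon. Among the compounds with values here, that step stays within the scatter, but it is only an indirect guide, since no measured pair exchanges a methyl for a methoxy. On the strength of a 1.1-fold lower number from compound 2 to compound 3 (0.02 log units; within the scatter), no shift beyond the scatter is expected in this assay. The expected size of the step is a 1.1-fold higher number from compound 3 to compound 4 (0.02 log units; within the scatter). For compound 4 the estimated value is 200 nM, with an expected range of 100 nM to 400 nM.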

Compound 4, half-maximal inhibitory concentration: 240 nM
Compound 4: the middle estimate sits 1.2-fold (0.08 log units) below what was measured, within the range that was stated.
By their numbers in this assay, from the lowest: compounds 3, 2, 4 and 1 (each within the scatter of the next).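

In this assay the exchange of 3,5-dimethylphenyl for 3-methoxyphenyl on a sulfonamide nitrogen gives a 1.3-fold higher number from compound 3 to compound 4 (0.10 log units; within the scatter) and the exchange of methyl for methoxy on an aromatic carbon gives a 1.2-fold higher number from compound 2 to compound 4 (0.08 log units; within the scatter). The earlier step had only put methyl in place of hydrogen, whereas these steps show that a group with a hydrogen-bond acceptor and an oxygen atom can enter here without a shift beyond the scatter in this assay. Nothing available offers an explanation for how close these values lie. The compounds shown leave open whether an amine or a carboxylic acid on this aromatic ring would move the number beyond the scatter. They also leave open what 3,5-dimethoxyphenyl would give on the same sulfonamide nitrogen.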